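The compounds below may be only part of what the source reports. "The series", "measured", "known", "first", "only" and "open" are said of these compounds alone.

Three analogues sharing one core have been measured in an assay on isolated protein for inhibition of extracellular serine/threonine protein kinase FAM20C (Homo sapiens), read by malachite green, tested at 10 uM, in the presence of a further agent that is not named here; on this read-out lower numbers stand for less inhibition and higher numbers for more inhibition at the one concentration tested (going by the name of the read-out). Compound 1 `COc1cc(C)cc(Cl)c1S(=O)(=O)Nc1ccc(Nc2nc(C)cc(Nc3ccc(F)cc3)n2)cc1` gives 12% in this assay. Among the compounds with values here, compound 2 `COc1ccc(Nc2cc(C)nc(Nc3ccc(NS(=O)(=O)c4c(Cl)cc(C)cc4OC)cc3)n2)cc1` gives 12% in this assay, so the only one-place step measured so far, methoxy in place of fluoro on an aromatic carbon, shows no change at the digits printed from compound 1 to compound 2 (within the scatter). Compound 3 `COc1ccc(Nc2ccnc(Nc3ccc(NS(=O)(=O)c4ccc(OC)cc4)cc3)n2)cc1` gives 25% in this assay, the highest of the three numbers and separated from both compound 1 and compound 2 by a margin beyond the scatter.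

The next compound, compound 4 `COc1ccc(Nc2ccnc(Nc3ccc(NS(=O)(=O)c4ccc(C(F)(F)F)cc4)cc3)n2)cc1`, differs from compound 3 in one place: trifluoromethyl in place of methoxy on an aromatic carbon. Within the data shown here, no measured step swaps methoxy for trifluoromethyl, and the one step that does exist, from compound 1 to compound 2, concerns methoxy against fluoro at a different place and lies within the scatter. On that thin evidence, the substitution is not expected to move the read-out in this assay by more than the usual scatter in either direction. Compound 4 is therefore estimated to give 20% in this assay, within a range from 5% to 38%. This corresponds to an expected a number 5 percentage points lower from compound 3 to compound 4 (within the scatter), a step that would sit inside the usual scatter.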

Compound 4, a percentage reported as inhibition, at one concentration (the size of the read-out at that concentration, not a potency): 18%
The estimate for compound 4 lay 2 percentage points above the measured number; the measured number falls inside the stated range.
By their numbers in this assay, from the lowest: compounds 1, 2, 4 and 3 (each within the scatter of the next, the first and the last beyond it).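

Going from 4-methoxyphenyl to 4-(trifluoromethyl)phenyl, on an aromatic carbon para to a large group, gives a number 7 percentage points lower from compound 3 to compound 4 (within the scatter) in this assay, and this is the first measured step at this position. The group that leaves has 2 heavy atoms and 1 hydrogen-bond acceptor, while the group that enters has 4 heavy atoms and 0 hydrogen-bond acceptors, yet this exchange does not separate the two compounds beyond the scatter on this read-out. No measurement shown here accounts for this outcome, so it stands as an observation without an explanation.

The compounds shown leave open whether a group of another kind at this position, such as an amine or a carboxylic acid, would move the read-out in this assay beyond the scatter. They also leave open which of the several differences between compound 3 and compound 1 goes with the gap between their values, and every number here is a single-concentration read-out rather than a potency.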